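Phenyl for trifluoromethyl on a sulfonyl sulfur

The source may report more compounds than this note shows. Statements on the series, on what has been measured and on what is new or still open speak of the compounds shown alone.

Compound 1 `CCN(CCn1cc[n+](C)c1/C=N/O)S(=O)(=O)C(F)(F)F`, compound 2 `C[n+]1ccn(CCCNS(=O)(=O)C(F)(F)F)c1/C=N/O` and compound 3 `CCN(CCn1cc[n+](C)c1/C=N/O)S(=O)(=O)c1ccccc1` have been measured in a physicochemical assay for lipophilicity; a higher number here means a more lipophilic compound, a lower number a more polar compound; compound 4 `C[n+]1ccn(CCCNS(=O)(=O)c2ccccc2)c1/C=N/O` has not. In this assay compound 1 gives -1.03, compound 2 gives -1.26 and compound 3 gives -1.39. Compound 3 differs from compound 1 by phenyl in place of trifluoromethyl on a sulfonyl sulfur, and this change made a step of a number 0.36 log units lower from compound 1 to compound 3 (beyond the scatter). The difference between the cores of compound 1 and compound 2 is not broken down here. Compound 4 differs from compound 2 by phenyl in place of trifluoromethyl on a sulfonyl sulfur, the same change at the same place. The step in this assay is expected to be a number 0.36 log units lower from compound 2 to compound 4 (beyond the scatter), resting on the measured step of a number 0.36 log units lower from compound 1 to compound 3 (beyond the scatter). Compound 4 is accordingly estimated at -1.62, between -2 and -1.25.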

Compound 4, distribution coefficient: -1.89
Beside the measured number, compound 4's estimate is 0.27 log units above it, within the range that was stated.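

In this assay, phenyl in place of trifluoromethyl on a sulfonyl sulfur lowers the number on both cores, with both steps beyond the scatter (a number 0.36 log units lower from compound 1 to compound 3 (beyond the scatter); a number 0.63 log units lower from compound 2 to compound 4 (beyond the scatter)). The direction therefore carried from one core to the other, but the size did not stay the same, and a single pair on each core does not establish a rule for the series. Nothing available explains the difference in size.

Still open, on these data alone, is whether a methyl group or an amine-bearing group on the sulfonyl sulfur would follow the same direction. Also open, as far as these compounds go, is whether the step holds on a core with a longer chain.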